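From Fluoro to Hydroxy: Expecting the Read-Out of Compound 4

The source may report more compounds than this note shows. Statements on the series, on what has been measured and on what is new or still open speak of the compounds shown alone.

Measured so far:
compound 1, `O=C(N/N=C/c1ccccc1F)c1cnccn1`, gives 81%
compound 2, `COc1ccc(/C=N/NC(=O)c2cnccn2)cc1`, gives 55%
compound 3, `CCOc1ccc(/C=N/NC(=O)c2cnccn2)cc1`, gives 100%

All three numbers come from an ADME assay on J774 cells (Mus musculus) for cytotoxicity, read by MTT assay, with a stated time of 48 h, tested at 150 ug/mL; a higher number here means a weaker effect of the compound at the concentration tested, a lower number a stronger effect. Among them compound 1 stands second highest of three. Its nearest neighbour is compound 3, whose number is higher than that of compound 1 by more than the usual scatter; furthest away is compound 2, whose number is lower than that of compound 1, again beyond the scatter.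

The unmeasured compound 4, `O=C(N/N=C/c1ccccc1O)c1cnccn1`, differs from compound 1 in one place: hydroxy in place of fluoro on an aromatic carbon.

For the measured compounds named here, only one step between measured compounds is known, the one from compound 2 to compound 3, which was a number 45 percentage points higher from compound 2 to compound 3 (beyond the scatter). That step concerns a methyl in place of hydrogen on a saturated chain carbon bound to an oxygen on an aromatic ring, a different kind of change from a hydroxy in place of fluoro, so it does not bear on the present step. With nothing comparable to lean on, the expectation for this assay is no step beyond the scatter: a number 1 percentage points lower from compound 1 to compound 4 (within the scatter). Compound 4 is therefore estimated at 80%, in the range from 55% to 100%.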

Compound 4, a percentage reported as activity, at one concentration (the size of the read-out at that concentration, not a potency): 0%
Compound 4: the middle estimate sits 80 percentage points above what was measured, outside the stated range (below it).
By their numbers in this assay, from the lowest: compound 4; then compound 2; then compound 1; then compound 3.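

The hydroxy in place of fluoro on an aromatic carbon, ortho to a large group, is a swap of one heavy atom for another, yet it gives a number 81 percentage points lower from compound 1 to compound 4 (beyond the scatter) in this assay, so this position is far from indifferent to what sits on it. The earlier step showed only that the read-out can respond to a small extension of a saturated chain, whereas this result shows that a similarly small change directly on the aromatic ring can also move it greatly; here the change adds 1 hydrogen-bond donor and 1 hydrogen-bond acceptor, and compound 4 reaches 0%, the lowest number of the four compounds. Nothing available explains why the exchange has so large an effect, and the counts alone cannot settle it.

From the compounds shown here alone, it remains open whether this drop is particular to hydroxy or would also appear with another group at the same place, such as an amine or a chlorine atom. The compounds shown also leave open whether hydroxy would have a comparable effect at another place on this ring.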